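This account rests on a few compounds, and the source may have more. Where it says the series, first, only, none or still open, it means among the compounds named here.

In a functional assay on K562 cells (Homo sapiens) for inhibition, read by trypan blue exclusion, with a stated time of 72 h (on this read-out higher numbers stand for weaker inhibition and lower numbers for stronger inhibition), compound 1 `Cn1c(=O)c(C(=O)Nc2ccc(F)cc2)cc2cnc(Nc3ccc4[nH]ccc4c3)nc21` gives 5000 nM and compound 2 `Cn1c(=O)c(S(=O)(=O)c2ccc(F)cc2)cc2cnc(Nc3ccc4[nH]ccc4c3)nc21` gives 200 nM, the lower of the two numbers. Compound 3 `Cc1ccc(S(=O)(=O)c2cc3cnc(Nc4ccc5[nH]ccc5c4)nc3n(C)c2=O)cc1` differs from compound 2 by methyl in place of fluoro on an aromatic carbon, para to a large group. Among the measured compounds shown here, the only measured step, a 25-fold lower number from compound 1 to compound 2 (1.40 log units; beyond the scatter), swapped (4-fluorophenyl)carbamoyl for (4-fluorophenyl)sulfonyl and kept the fluoro, so it gives no size for this change, and no step beyond the scatter is expected in this assay. The expected step is no change at the digits printed from compound 2 to compound 3 (within the scatter). Compound 3 is estimated at 200 nM, with an expected range of 70 nM to 600 nM.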

Compound 3, half-maximal inhibitory concentration: 750 nM
Compound 3: the middle estimate sits 3.8-fold (0.57 log units) below what was measured; the whole stated range lies below it.
By their numbers in this assay, from the lowest: compound 2; then compound 3; then compound 1.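

In this assay methyl in place of fluoro on this aromatic carbon, para to a large group, gives a 3.8-fold higher number from compound 2 to compound 3 (0.57 log units; beyond the scatter) and so is a change the read-out registers. The sulfonyl compound with methyl still keeps an edge over the carbamoyl compound with fluoro, with a 6.7-fold lower number from compound 1 to compound 3 (0.82 log units; beyond the scatter) and a smaller gap than the one between the two fluoro compounds. No measurement here offers an explanation for the loss on moving to methyl.

As far as these compounds go, whether methoxy, an amine or a longer chain at this carbon would fall closer to fluoro or to methyl remains open.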